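The source may report more compounds than this note shows. Statements on the series, on what has been measured and on what is new or still open speak of the compounds shown alone.

Within the data shown here, in an ADME assay on microsomes from liver (Mus musculus) for metabolic stability, read by LC-MS, with a stated time of 10 min, tested at 500 uM (on this read-out lower numbers stand for a less stable compound and higher numbers for a more stable compound), compound 1 (`COc1cc2c(cc1OC)CN(c1cccnc1)CC2`) gives 9.5%, the lower of the two numbers so far. Compound 2 (`COc1cc2c(cc1OC)CN(c1cc(C(F)(F)F)cc(C(F)(F)F)c1)CC2`) gives 83.1%, a gap well beyond the scatter. Among the measured compounds shown here, no measured pair provides a step that could scale the next move. Compound 3 (`COc1cc2c(cc1OC)CN(c1ccccn1)CC2`) keeps the core of compound 1 and carries pyridin-2-yl in place of pyridin-3-yl on an amine nitrogen in a ring. For the measured compounds named here, the two have the same atoms, joined differently, and nothing measured so far isolates this kind of change. With compound 1 at 9.5%, little room remains downward, so a modest rise in this assay is expected, only slightly beyond the scatter. The expected change is a number 12.5 percentage points higher from compound 1 to compound 3 (beyond the scatter). For compound 3 the estimated value is 22%, with an expected range of 6% to 45%.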

Compound 3, percent of the compound remaining: 9.9%
For compound 3 the middle estimate is 12.1 percentage points above the measured one, and the stated range covers the measured number.
By their numbers in this assay, from the lowest: compounds 1 and 3 (each within the scatter of the next); then compound 2.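

Among these compounds, exchanging pyridin-3-yl for pyridin-2-yl on the amine nitrogen in a ring gives a number 0.4 percentage points higher from compound 1 to compound 3 (within the scatter) in this assay and is the first single-place step. At this position, the two pyridinyl attachments cannot be told apart on this read-out, so this exchange offers no separation between compound 1 and compound 3. No measurement at hand bears on why the two compounds read alike.

Open, from the compounds shown here alone, is whether pyridin-4-yl or a phenyl ring carrying a single trifluoromethyl group at the same amine nitrogen would stay with these two compounds or approach compound 2 at 83.1%. Also open, going by these compounds, is what an ethoxy group in place of a methoxy group on the shared core would do with pyridin-3-yl kept.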